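The source may report more compounds than this note shows. Statements on the series, on what has been measured and on what is new or still open speak of the compounds shown alone.

Series notes. Compound 1 `O=C(CCCNCC1CCCCC1)N1CCN(C(c2ccccc2)c2ccc(Cl)cc2)CC1` and compound 2 `O=C(CCCNCc1ccccc1)N1CCN(C(c2ccccc2)c2ccc(Cl)cc2)CC1` share the core and differ only in the ring on the chain carbon bound to the amine nitrogen. Among the measured compounds shown here, in an assay on HEK293 cells for inhibition of Voltage-dependent T-type calcium channel subunit alpha-1G (Homo sapiens), read by patch clamp (on this read-out higher numbers stand for weaker inhibition and lower numbers for stronger inhibition), compound 1 gives 190 nM, and compound 2 gives 1670 nM; the step of an 8.8-fold higher number from compound 1 to compound 2 (0.94 log units; beyond the scatter) puts compound 2 at the highest of the two numbers so far, with compound 1 as its only neighbour.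

Compound 3 `O=C(CCCNCc1ccc([N+](=O)[O-])cc1)N1CCN(C(c2ccccc2)c2ccc(Cl)cc2)CC1` is not yet measured. It differs from compound 2 by nitro in place of hydrogen on an aromatic carbon. For the measured compounds named here, the one measured step, an 8.8-fold higher number from compound 1 to compound 2 (0.94 log units; beyond the scatter), exchanges the ring itself and says nothing about a substituent on the phenyl ring, so no measured step bears directly on this change. Without such a precedent, the expectation in this assay is a step near the scatter, in no firm direction, so compound 3 is expected around 1500 nM, between 500 nM and 4500 nM, corresponding to an estimated step of a 1.1-fold lower number from compound 2 to compound 3 (0.05 log units; within the scatter).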

Compound 3, half-maximal inhibitory concentration: 600 nM
Compound 3: the middle estimate sits 2.5-fold (0.40 log units) above what was measured; the range from low to high includes it.
By their numbers in this assay, from the lowest: compound 1; then compound 3; then compound 2.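

In this assay, among the compounds shown here, the aromatic carbon para to a large group responds to substitution: nitro in place of hydrogen gives a 2.8-fold lower number from compound 2 to compound 3 (0.44 log units; beyond the scatter), beyond the scatter and the first measured change on the phenyl ring rather than an exchange of the ring itself. This gain does not fully offset the ring exchange, since 4-nitrophenyl in place of cyclohexyl still gives a 3.2-fold higher number from compound 1 to compound 3 (0.50 log units; beyond the scatter), so the cyclohexyl compound remains ahead of both aromatic compounds. Nothing available explains why nitro shifts the number in this direction.

As far as these compounds go, whether this shift is particular to nitro remains open, since an amine, a carboxylic acid or a methoxy group at the same carbon could read differently. Also open, from the compounds shown here alone, is how a longer chain between the amine nitrogen and the ring would read in this assay.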